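Working notes: solubility across the shared core

The source may hold more compounds than are shown below. What is called first, only, known or untested is meant among the compounds shown, and "the series" means these compounds.

Compound 1 `Cc1cc(NC(=O)Nc2ccc(C)c(Cl)c2)c2ccccc2n1`: 300 nM
Compound 2 `COc1ccc(NC(=O)Nc2cc(C)nc3ccccc23)cc1`: 19800 nM
Compound 3 `Cc1cc(NC(=O)Nc2cccc(Cl)c2)c2ccccc2n1`: 800 nM

In a physicochemical assay for solubility, at pH 7.4 (a higher number here means a more soluble compound, a lower number a less soluble compound), compound 3 stands second highest of the three, below compound 2 and above compound 1. Compound 4 `COc1ccc(NC(=O)Nc2cc(C)nc3ccccc23)cc1Cl` differs from compound 3 by methoxy in place of hydrogen on an aromatic carbon. Among the measured compounds shown here, the only measured step, a 2.7-fold higher number from compound 1 to compound 3 (0.43 log units; beyond the scatter), concerns a different change and bears on this one only loosely. For the measured compounds named here, no step is recorded between compound 2 and compound 3, but compound 2 carries a methoxy and shows a far higher number, so a rise in this assay is expected for compound 4, tempered by the chloro it keeps. The estimate for compound 4 is 4000 nM, range 1200 nM to 13000 nM, an expected step of a 5.0-fold higher number from compound 3 to compound 4 (0.70 log units; beyond the scatter).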

Compound 4, solubility: 400 nM
Beside the measured number, compound 4's estimate is 10-fold (1.00 log units) above it; measured number outside the range, below it.
By their numbers in this assay, from the lowest: compounds 1, 4 and 3 (each within the scatter of the next, the first and the last beyond it); then compound 2.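

In this assay, methoxy in place of hydrogen, ortho to a chloro group and para to a large group, gives a step within the scatter (a 2.0-fold lower number from compound 3 to compound 4 (0.30 log units; within the scatter)), so with the chloro present this change is not resolved here. Methoxy in place of methyl likewise stays within the scatter (a 1.3-fold higher number from compound 1 to compound 4 (0.12 log units; within the scatter)), whereas chloro in place of hydrogen gives the large step (a 50-fold lower number from compound 2 to compound 4 (1.69 log units; beyond the scatter)). No measurement accounts for these steps. Open, as far as these compounds go, is whether an amine or a carboxylic acid in place of the methoxy would give a step beyond the scatter in the presence of the chloro.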